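Core substituent: methylsulfanyl replacing amino at position of compound 3

This account rests on a few compounds, and the source may have more. Where it says the series, first, only, none or still open, it means among the compounds named here.

Measured in an assay on a protein complex for inhibition of ubiquitin carboxyl-terminal hydrolase 1/WD repeat-containing protein 48 (Homo sapiens), read by fluorescence; a higher number here means a weaker inhibitor, a lower number a stronger inhibitor:
compound 1 `Cc1cnc(-c2ccccc2C(C)C)nc1NCc1ccc(-c2cccnc2)cc1`: 70 nM
compound 2 `COc1cnc(-c2ccccc2C(C)C)nc1NCc1ccc(-c2cccnc2)cc1`: 70 nM
compound 3 `CC(C)c1ccccc1-c1ncc(N)c(NCc2ccc(-c3cccnc3)cc2)n1`: 310 nM

Compound 3 gives the highest number of the three in this assay; the gap to compound 1 and to compound 2 is the same size in each case and lies beyond the scatter, so compound 3 is the weakest inhibitor of the measured set.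

Compound 4 `CSc1cnc(-c2ccccc2C(C)C)nc1NCc1ccc(-c2cccnc2)cc1` differs from compound 3 in one place: methylsulfanyl in place of amino on an aromatic carbon.

Among the measured compounds shown here, three measured steps bear on this. The methyl and methoxy groups at this position behave alike: no change at the digits printed from compound 1 to compound 2 (within the scatter). Amino at the same position costs potency in both comparisons: a 4.4-fold higher number from compound 1 to compound 3 (0.65 log units; beyond the scatter) and a 4.4-fold higher number from compound 2 to compound 3 (0.65 log units; beyond the scatter). Methylsulfanyl, like methyl and methoxy, carries no hydrogen-bond donor, so the reasonable expectation is that compound 4 recovers most of what compound 3 lost, with a step of modest size in the direction of a lower number in this assay. No sulfur-bearing substituent has yet been measured in this series, so the recovery is not guaranteed to be complete.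

The expected step is a 3.4-fold lower number from compound 3 to compound 4 (0.54 log units; beyond the scatter). Compound 4 is therefore estimated at 90 nM in this assay, with a range of 35 nM to 280 nM.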

Compound 4, half-maximal inhibitory concentration: 110 nM
Compound 4: middle estimate off by 1.2-fold (0.09 log units), on the low side; the range from low to high includes it.
By their numbers in this assay, from the lowest: compounds 1, 2 and 4 (each within the scatter of the next); then compound 3.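

In this assay, methylsulfanyl at this position gives a 2.8-fold lower number from compound 3 to compound 4 (0.45 log units; beyond the scatter), so the drop seen with amino does not extend to this first sulfur-bearing substituent. Against the other two groups the readings are a 1.6-fold higher number from compound 2 to compound 4 (0.20 log units; within the scatter) and a 1.6-fold higher number from compound 1 to compound 4 (0.20 log units; within the scatter), which places methylsulfanyl, methoxy and methyl in one band that this assay cannot separate, with amino alone standing apart among the four compounds. Nothing in hand explains why amino stands apart, even though the change from compound 3 to compound 4 removes a hydrogen-bond donor.

The compounds shown leave open whether that donor is what separates amino from the other groups, a question that a comparison of methylamino with dimethylamino at this position would address. They also leave open how far the band extends, for instance to a longer chain such as ethylsulfanyl, to a methylsulfonyl group, or to a halogen such as chlorine.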